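The source may hold more compounds than are shown below. What is called first, only, known or untested is meant among the compounds shown, and "the series" means these compounds.

Compound 1 `CCC(c1ccccc1)c1nc(-c2ccc(Cl)cc2)c(CC(=O)O)s1` was run in an in vitro functional assay on HEK285-7 cells for antagonist activity at prostaglandin D2 receptor 2 (Homo sapiens), read by BRET and beta-arrestin recruitment; a higher number here means a weaker inhibitor, a lower number a stronger inhibitor. In this assay compound 1 gives > 100000 nM, which is a limit of the assay and not a number. Compound 2 `O=C(O)Cc1sc(C(c2ccccc2)c2ccc(Cl)cc2)nc1-c1ccc(Cl)cc1` carries a 4-chlorophenyl in place of the ethyl on the saturated chain carbon bound to two aromatic carbons, and in this assay compound 2 gives 75 nM. The step of an at least 1300-fold lower number from compound 1 to compound 2 (3.12 log units; beyond the scatter) can only be given as a lower bound because compound 1 sits at the limit of > 100000 nM in this assay, at which 1 of the 2 values shown sits. Compound 2 therefore stands at the only number shown in this assay; the other value shown is a limit.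

Compound 3 `O=C(O)Cc1sc(C(c2ccccc2)c2ccc(Cl)cc2)nc1-c1ccc(F)cc1` differs from compound 2 by fluoro in place of chloro on an aromatic carbon. Going by the values given here, the one measured step changes the saturated chain carbon and leaves the chloro on the aromatic carbon untouched, so no measured step speaks directly to the exchange of chloro for fluoro at that place; the shared core and the groups on the chain carbon of compound 2 are kept. Among the compounds with values here, with no measured step at this position, the expected step in this assay is a 1.5-fold higher number from compound 2 to compound 3 (0.17 log units; within the scatter), not beyond the scatter. Compound 3 is accordingly estimated at 110 nM, with a range from 30 nM to 400 nM.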

Compound 3, half-maximal inhibitory concentration: 79 nM
The estimate for compound 3 lay 1.4-fold (0.14 log units) above the measured number; the range from low to high includes it.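

In this assay, going by these compounds alone, the exchange of chloro for fluoro on the aromatic carbon, para to a large group, gives a 1.1-fold higher number from compound 2 to compound 3 (0.02 log units; within the scatter), the first measured step at this position. Within these two compounds, the 4-chlorophenyl and the 4-fluorophenyl read alike, whereas the only earlier step concerned the saturated chain carbon, and this reading rests on a single pair of compounds. The data shown offer no explanation for how this step reads.

Still open, on these data alone, is how this position responds to groups other than these two halogens, such as bromo, methoxy, a nitrile, an amine or a plain hydrogen, so the tolerance seen here cannot yet be extended beyond chloro and fluoro. Also open, as far as these compounds go, is whether the same exchange reads alike on the 4-chlorophenyl at the saturated chain carbon, and whether the carboxylic acid on the shared core can give way to an amide or sit on a longer chain.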